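The compounds below may be only part of what the source reports. "The series", "measured", "known", "first", "only" and "open" are said of these compounds alone.

In an ADME assay on microsomes from liver (Canis lupus familiaris) for metabolic stability, with a stated time of 10 min (a higher number here means that more of the compound is left, a lower number that less of the compound is left), compound 1 `FC(F)(F)Oc1ccccc1-c1ccc2[nH]c(C3=NOC4(CCCCC4)C3)nc2c1` gives 81%, and compound 2 `FC(F)Oc1ccccc1-c1ccc2[nH]c(C3=NOC4(CCCCC4)C3)nc2c1` gives 81%, so the two stand level. Compound 3 `Fc1cccc(OC(F)(F)F)c1-c1ccc2[nH]c(C3=NOC4(CCCCC4)C3)nc2c1` keeps the core of compound 1 and carries one change: fluoro in place of hydrogen on an aromatic carbon. Among the compounds with values here, the sole measured step, no change at the digits printed from compound 1 to compound 2 (within the scatter), lies on a saturated chain carbon, not on an aromatic carbon, so it bears on this change only loosely. On that evidence no shift beyond the scatter is expected, and the estimated step is a number 1 percentage points lower from compound 1 to compound 3 (within the scatter). Compound 3 is expected at 80%, with an estimated range of 66% to 92%.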

Compound 3, percent of the compound remaining: 73%
Beside the measured number, compound 3's estimate is 7 percentage points above it; the measured number falls inside the stated range.
By their numbers in this assay, from the lowest: compounds 3, 1 and 2 (each within the scatter of the next).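

In this assay, fluoro in place of hydrogen on this aromatic carbon, ortho to a large group and meta to a trifluoromethoxy group, gives a number 8 percentage points lower from compound 1 to compound 3 (within the scatter), so the position takes the fluoro without a shift beyond the scatter. Within the data shown here, the earlier step lay on a saturated chain carbon, so this is the only step that speaks for the aromatic carbon itself. Nothing at hand offers an explanation for this step.

Open, going by these compounds, is how a methyl, a methoxy or an amine on the same aromatic carbon would fare. Also open, on these data alone, is whether fluoro there gives a similar step alongside the difluoromethoxy group of compound 2.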